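The source may hold more compounds than are shown below. What is called first, only, known or untested is meant among the compounds shown, and "the series" means these compounds.

Measured compounds in a functional assay on HeLa cells (Homo sapiens) for antiproliferative activity, read by MTT assay, with a stated time of 48 h; a higher number here means a weaker inhibitor of growth, a lower number a stronger inhibitor of growth:
compound 1, `CCOC(=O)c1sc2ccc(NCc3c[nH]cn3)cc2c1NC(=O)c1ccc(OC)cc1`, gives 12900 nM
compound 2, `CCOC(=O)c1sc2ccc(NCc3c[nH]cn3)cc2c1NC(=O)c1ccc(C)cc1`, gives 11700 nM
compound 3, `CCOC(=O)c1sc2ccc(NCc3c[nH]cn3)cc2c1NC(=O)c1cc(OC)c(OC)c(OC)c1`, gives 6790 nM

All three share one core and differ only in the aryl group on the amide carbonyl. Compound 3 stands at the lowest number of the three in this assay, but the gaps to the other two are small: a 1.9-fold lower number from compound 1 to compound 3 (0.28 log units; within the scatter) and a 1.7-fold lower number from compound 2 to compound 3 (0.24 log units; within the scatter), both within the scatter, as is a 1.1-fold lower number from compound 1 to compound 2 (0.04 log units; within the scatter). Among the compounds with values here, nothing among the measured compounds separates one aryl group from another beyond the noise of the assay.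

Compound 4, `CCOC(=O)c1sc2ccc(NCc3c[nH]cn3)cc2c1NC(=O)c1ccc(C(F)(F)F)cc1`, is the next variation at the same position: 4-(trifluoromethyl)phenyl in place of 3,4,5-trimethoxyphenyl on a carbonyl carbon. The three measured steps all exchange substituents on this same aromatic ring, and each of them stayed within the scatter, so the same is expected here, with no direction favoured. Compound 4 is therefore expected to land close to its neighbours in this assay, around 9500 nM, with a range of 4000 nM to 22000 nM. The implied step from compound 3 to compound 4 is estimated as a 1.4-fold higher number from compound 3 to compound 4 (0.15 log units; within the scatter), a shift not expected to exceed the scatter.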

Compound 4, concentration for 50% growth inhibition: 16800 nM
Estimate against measurement, compound 4: 1.8-fold (0.25 log units) below; low and high end bracket the measured number.
By their numbers in this assay, from the lowest: compounds 3, 2, 1 and 4 (each within the scatter of the next, the first and the last beyond it).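

In this assay, within the data shown here, the aryl group on the carbonyl carbon now gives the first step beyond the scatter, with a 2.5-fold higher number from compound 3 to compound 4 (0.39 log units; beyond the scatter) for 4-(trifluoromethyl)phenyl in place of 3,4,5-trimethoxyphenyl, so this position is not entirely silent. The separation holds only for that one exchange: trifluoromethyl in place of methyl gives a 1.4-fold higher number from compound 2 to compound 4 (0.16 log units; within the scatter) and trifluoromethyl in place of methoxy gives a 1.3-fold higher number from compound 1 to compound 4 (0.11 log units; within the scatter) and both of these stay within the scatter, leaving compound 1 and compound 2 unresolved from either end of the series. The exchange removes three methoxy groups and brings in three fluorine atoms in one move, and nothing available on the compounds separates these changes or explains the step.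

Open, on these data alone, is whether the gap depends on the full 3,4,5-trimethoxyphenyl pattern or mainly on the trifluoromethyl group, as compound 1 and compound 2 cannot settle this. Also open, as far as these compounds go, is how an aryl group bearing an amine or a carboxylic acid, or a longer alkyl chain on the carbonyl carbon in place of the aryl ring, would read in this assay on the shared core.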